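Adding a Chlorine to the Core of Compound 3

A few compounds are considered here, and "the series" means these few. Any claim that something is new, unique, unknown or untested is made for them only; others in the source may bear on it.

Compound 3 `O=C1Nc2ccccc2/C1=C\c1c(Cl)n(CCCc2ccccc2)c2ccccc12` was tested in a functional assay on cells (Cancer cell lines, Homo sapiens) for cytotoxicity, with a stated time of 48 h (a higher number here means a weaker inhibitor of growth, a lower number a stronger inhibitor of growth), where compound 3 gives 12000 nM. Among the three measured compounds this is the second highest number. Compound 1 `O=C1Nc2ccccc2/C1=C\c1c(Cl)n(Cc2ccccc2)c2ccccc12` gives 20000 nM in this assay, and the step of a 1.7-fold lower number from compound 1 to compound 3 (0.22 log units; within the scatter) places the two within the scatter of each other. For the measured compounds named here, compound 2 `COc1cc2c(/C=C3/C(=O)Nc4cccc(Cl)c43)c(Cl)n(Cc3cc(OC)c(OC)c(OC)c3)c2cc1C` gives 2880 nM in this assay, a number beyond the scatter below that of compound 3, but compound 2 differs from compound 3 in several places at once, so no single step between them can be read off.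

Compound 4 `O=C1Nc2ccc(Cl)cc2/C1=C\c1c(Cl)n(CCCc2ccccc2)c2ccccc12` differs from compound 3 in one place only: chloro in place of hydrogen on an aromatic carbon. Going by the values given here, the one measured step, a 1.7-fold lower number from compound 1 to compound 3 (0.22 log units; within the scatter), concerns the chain on the aromatic nitrogen and says nothing about this ring position, so no measured step bears on the change directly. In the absence of such a step, the step of a 1.3-fold lower number from compound 3 to compound 4 (0.12 log units; within the scatter) is expected to stay within the scatter. Compound 4 is therefore estimated at 9000 nM, with a range from 3500 nM to 25000 nM.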

Compound 4, concentration for 50% growth inhibition: 1950 nM
The estimate for compound 4 lay 4.6-fold (0.66 log units) above the measured number; measured number below the stated range.
By their numbers in this assay, from the lowest: compounds 4 and 2 (each within the scatter of the next); then compounds 3 and 1 (each within the scatter of the next).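

In this assay, the step of a 6.2-fold lower number from compound 3 to compound 4 (0.79 log units; beyond the scatter) is the only step among these compounds that lies beyond the scatter. It comes from a single chlorine atom that replaces a hydrogen atom on the six-membered aromatic ring of carbon only. The one earlier step changed the chain on the aromatic nitrogen and stayed within the scatter, so this ring carbon is the first place shown where one small change clearly moves the number, and nothing available here explains the size of this step.

On these data alone, it remains open whether another group on this carbon, such as fluoro, a nitrile or an amine, would give a number close to that of chloro. As far as these compounds go, it is also open whether chloro here would give a similar step with the chain of compound 1 on the aromatic nitrogen.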